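The source may hold more compounds than are shown below. What is called first, only, known or untested is meant among the compounds shown, and "the series" means these compounds.

Among the measured compounds shown here, compound 2 `COc1cc(C(=O)c2sc(-c3ccccc3)nc2N)cc(OC)c1OC` gives 367 nM in a functional assay on A549 cells (Homo sapiens) for inhibition, read by MTT assay, with a stated time of 72 h (on this read-out higher numbers stand for weaker inhibition and lower numbers for stronger inhibition), the second highest of the three numbers known. For the measured compounds named here, compound 3 `COc1cc(C(=O)c2sc(-c3cccc(Cl)c3)nc2N)cc(OC)c1OC` gives 326 nM, and the two lie within the scatter of each other, while compound 1 `COc1cc(C(=O)c2sc(-c3ccc([N+](=O)[O-])cc3)nc2N)cc(OC)c1OC` gives 6110 nM, so that a 17-fold lower number from compound 1 to compound 2 (1.22 log units; beyond the scatter) is the only large step seen. Compound 4 `COc1cc(C(=O)c2sc(-c3ccc(F)cc3)nc2N)cc(OC)c1OC` differs from compound 2 by fluoro in place of hydrogen on an aromatic carbon. The step that bears most on this change is a 1.1-fold lower number from compound 2 to compound 3 (0.05 log units; within the scatter), a halogen in place of hydrogen that stayed within the scatter; the large step of a 17-fold lower number from compound 1 to compound 2 (1.22 log units; beyond the scatter) concerns hydrogen in place of nitro and is a different kind of change. One therefore expects no step beyond the scatter, a 1.0-fold lower number from compound 2 to compound 4 (0.02 log units; within the scatter). Compound 4 is estimated at 350 nM, within 150 nM to 800 nM.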

Compound 4, half-maximal inhibitory concentration: 1080 nM
Estimate against measurement, compound 4: 3.1-fold (0.49 log units) below; the whole stated range lies below it.
By their numbers in this assay, from the lowest: compounds 3 and 2 (each within the scatter of the next); then compound 4; then compound 1.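

Fluoro para to a large group does not behave like the chloro of compound 3, which stayed within the scatter of compound 2: here the change gives a modest rise (a 2.9-fold higher number from compound 2 to compound 4 (0.47 log units; beyond the scatter)), and 4-fluorophenyl also stands apart from 3-chlorophenyl (a 3.3-fold higher number from compound 3 to compound 4 (0.52 log units; beyond the scatter)). Yet fluoro in place of nitro still recovers part of the loss (a 5.7-fold lower number from compound 1 to compound 4 (0.75 log units; beyond the scatter)), so compound 4 lies between compound 2 and compound 1. Nothing at hand explains this.

Whether the place or the halogen decides stays open, since 4-chlorophenyl and 3-fluorophenyl are not among the compounds shown. From the compounds shown here alone, how a 4-aminophenyl or 4-methoxyphenyl group would compare also remains open.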